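Aryl thioether in place of aryl ether on the diamino core

The source may report more compounds than this note shows. Statements on the series, on what has been measured and on what is new or still open speak of the compounds shown alone.

Compound 1 `Nc1cc(N)c2nc(-c3ccccc3)c(Oc3ccc(Cl)c(Cl)c3)nc2c1` is known in a functional assay on NCI-H522 cells (Homo sapiens) for inhibition, read by sulforhodamine B assay, with a stated time of 48 h (on this read-out lower numbers stand for higher toxicity in this test and higher numbers for lower toxicity in this test), only as a limit, < 100000 nM. Compound 2 `COc1cc(CNc2nc3cc(N)cc(N)c3nc2-c2ccccc2)cc(OC)c1OC` is also known only as a limit, < 50200 nM. Compound 3 `CCOC(=O)[C@H](CCC(=O)O)NC(=O)c1ccc(Oc2nc3cc(N)cc(N)c3nc2-c2ccccc2)cc1` likewise gives only a limit, < 100000 nM. No number exists for any of the three: two values sit at the limit of < 100000 nM in this assay, at which 2 of the 3 values shown sit, and one at the limit of < 50200 nM in this assay, at which 1 of the 3 values shown sits, so compound 1 can be placed only as sharing the higher limit with compound 3.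

Compound 4 `Nc1cc(N)c2nc(-c3ccccc3)c(Sc3ccc(F)cc3)nc2c1` differs from compound 1 by (4-fluorophenyl)sulfanyl in place of 3,4-dichlorophenoxy on an aromatic carbon, in words (4-fluorophenyl)sulfanyl in place of 3,4-dichlorophenoxy on an aromatic carbon. Among the measured compounds shown here, with no measured step in this assay, the expected step that the limit leaves unreadable from compound 1 to compound 4 is taken as none beyond the scatter. Compound 4 is expected near 60000 nM, between 10000 nM and 200000 nM, and most likely reported again only as a limit.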

Compound 4, concentration lethal to 50% of the cells: < 100000 nM
Compound 4: no number, only a limit; the forecaster's own chance of this, stated with the estimate: 70%; the middle value is on the limit's open side.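

In this assay compound 4 gives < 100000 nM, a limit and not a number. Among the compounds shown here, compound 1 also has only a limit, so no step from compound 1 to compound 4 can be read. As far as these compounds go, the actual lethal concentrations of all four compounds, and the effect of (4-fluorophenyl)sulfanyl in place of 3,4-dichlorophenoxy, stay open.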